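Removing a methyl from the ether side chain

The source may report more compounds than this note shows. Statements on the series, on what has been measured and on what is new or still open speak of the compounds shown alone.

Compound 1 `C=C(CCCC)C(=O)c1ccc(OCC(=O)OC)c(C)c1C` and compound 2 `C=C(CCCC)C(=O)c1ccc(OC(C)C(=O)OC)c(C)c1C` share one core and differ only in the side chain. In a functional assay on HL-60 cells (Homo sapiens) for antiproliferative activity, with a stated time of 72 h (a higher number here means a weaker inhibitor of growth, a lower number a stronger inhibitor of growth), compound 2 gives 5200 nM. In this assay compound 1 gives 8600 nM. The change hydrogen in place of methyl on a saturated chain carbon bound to a carbonyl carbon and an oxygen on an aromatic ring thus made a step of a 1.7-fold higher number from compound 2 to compound 1 (0.22 log units; within the scatter). Compound 3 `C=C(C)C(=O)c1ccc(OC(C)C(=O)O)cc1C` carries a different core; the difference between the two cores is not broken down here. In this assay compound 3 reaches only > 60000 nM, which is a limit of the assay and not a number, the one noted as the limit of > 60000 nM in this assay, at which 1 of the 3 values shown sits. Compound 4 `C=C(C)C(=O)c1ccc(OCC(=O)O)cc1C` arises from compound 3 by the same change, (hydrogen in place of methyl on a saturated chain carbon bound to a carbonyl carbon and an oxygen on an aromatic ring). Because the earlier step of a 1.7-fold higher number from compound 2 to compound 1 (0.22 log units; within the scatter) stayed within the scatter, the step expected from the change is a step that the limit leaves unreadable from compound 3 to compound 4. Compound 4 is therefore estimated at 100000 nM in this assay, most likely again only a limit.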

Compound 4, concentration for 50% growth inhibition: > 60000 nM
Compound 4 ended at the assay's limit; the forecaster's own chance of this, stated with the estimate: 85%; the middle value is on the limit's open side.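

In this assay compound 3 and compound 4 both stand at a limit and not at a number, so no step between them can be read: the limit of > 60000 nM in this assay, at which 2 of the 4 values shown sit.

Going by these compounds, whether hydrogen in place of methyl changes growth inhibition on the core of compound 3 stays open.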